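The compounds below may be only part of what the source reports. "The series", "measured", "known", "first", "only" and "open" are said of these compounds alone.

Compound 1 `C=C(Br)C(=O)Nc1ccc(/C=C/C(=O)c2ccc(OC)cc2)cc1`: 1300 nM
Compound 2 `C=C(Br)C(=O)Nc1ccc(/C=C/C(=O)c2cccc(OC)c2)cc1`: 850 nM
Compound 3 `C=C(Br)C(=O)Nc1ccc(C(=O)/C=C/c2ccc(OC)cc2)cc1`: 610 nM

All three were tested in a functional assay on MOLT-4 cells (Homo sapiens) for antiproliferative activity, with a stated time of 48 h; on this read-out higher numbers stand for weaker inhibition and lower numbers for stronger inhibition. The change 3-methoxyphenyl in place of 4-methoxyphenyl on a carbonyl carbon gave a 1.5-fold lower number from compound 1 to compound 2 (0.18 log units; within the scatter). Compound 3 has the lowest of the three numbers, but its value and that of compound 2 lie within the scatter of each other. The difference between the core of compound 1 and the core of compound 3 is not broken down here.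

Compound 4 `C=C(Br)C(=O)Nc1ccc(C(=O)/C=C/c2cccc(OC)c2)cc1` has not been measured. It carries the same kind of change, (3-methoxyphenyl in place of 4-methoxyphenyl on a double-bonded chain carbon bound to a double-bonded chain carbon), but not the same one: in the earlier pair the change sits on a carbonyl carbon whose other neighbour is a double-bonded chain carbon, here on a double-bonded chain carbon bound to a double-bonded chain carbon. Because a 1.5-fold lower number from compound 1 to compound 2 (0.18 log units; within the scatter) stayed within the scatter, compound 4 is expected to show a similarly small step, a 1.3-fold lower number from compound 3 to compound 4 (0.11 log units; within the scatter). Compound 4 is estimated at 470 nM, between 200 nM and 1100 nM.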

Compound 4, half-maximal inhibitory concentration: 1100 nM
Beside the measured number, compound 4's estimate is 2.3-fold (0.37 log units) below it; measured number inside the range.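

In this assay, 3-methoxyphenyl in place of 4-methoxyphenyl gave a 1.8-fold higher number from compound 3 to compound 4 (0.26 log units; within the scatter), and the two steps set side by side do not agree: the same change on two cores in this assay, a 1.5-fold lower number (0.18 log units; within the scatter) from compound 1 to compound 2 and a 1.8-fold higher number (0.26 log units; within the scatter) from compound 3 to compound 4, 2.8-fold (0.44 log units) apart, beyond the scatter of two such steps. The change therefore did not carry over from the core of compound 1 to the core of compound 3 as one fixed step. Each step alone stays within the scatter, however, so neither shows a real effect of the change on its own core, and the two pairs do not explain the gap between them. The compounds shown leave open how an amine or a carboxylic acid in place of the methoxy group would behave on either core.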